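Bromo in place of trifluoromethyl on the benzyl arm

The compounds below may be only part of what the source reports. "The series", "measured", "known", "first", "only" and "open" are said of these compounds alone.

Compound 1 `Cc1cc(Nc2cc(-c3ccccc3)[nH]n2)n2nc(SCCCc3ccccc3)nc2n1`: 6510 nM
Compound 2 `Cc1cc(Nc2cc(-c3ccccc3)[nH]n2)n2nc(SCc3ccc(Cl)cc3)nc2n1`: 3950 nM
Compound 3 `Cc1cc(Nc2cc(-c3ccccc3)[nH]n2)n2nc(SCc3ccc(C(F)(F)F)cc3)nc2n1`: 3520 nM

Of the compounds shown here, three sharing one core have been measured in a functional assay on MGC-803 cells (Homo sapiens) for inhibition, read by MTT assay, with a stated time of 72 h (a lower number here means a stronger inhibitor, a higher number a weaker inhibitor), and they differ only in the group attached to the sulfur. Compound 3 carries a 4-(trifluoromethyl)benzyl there and gives the lowest of the three numbers, but its neighbours sit close: the step of a 1.8-fold lower number from compound 1 to compound 3 (0.27 log units; within the scatter) and the step of a 1.1-fold lower number from compound 2 to compound 3 (0.05 log units; within the scatter) are both within the scatter, so compound 3 cannot be called stronger than either.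

Compound 4 `Cc1cc(Nc2cc(-c3ccccc3)[nH]n2)n2nc(SCc3ccc(Br)cc3)nc2n1` has not yet been measured. It differs from compound 3 in one place: bromo in place of trifluoromethyl on an aromatic carbon. The change sits on an aromatic carbon of a six-membered aromatic ring of carbon only, para to a large group.

The step that bears most directly on this is a 1.1-fold lower number from compound 2 to compound 3 (0.05 log units; within the scatter), where a halogen and trifluoromethyl at the same spot gave numbers within the scatter of each other. Bromo is a halogen like chloro, so the exchange for compound 4 is expected to move the number little, in no settled direction, with a 1.1-fold higher number from compound 3 to compound 4 (0.02 log units; within the scatter) as the estimated step. Compound 4 is therefore estimated at 3700 nM, with a range from 1800 nM to 7500 nM.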

Compound 4, half-maximal inhibitory concentration: 1110 nM
Beside the measured number, compound 4's estimate is 3.3-fold (0.52 log units) above it; measured number outside the range, below it.
By their numbers in this assay, from the lowest: compound 4; then compounds 3, 2 and 1 (each within the scatter of the next).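

In this assay the group on this aromatic carbon does matter: bromo in place of trifluoromethyl gives a 3.2-fold lower number from compound 3 to compound 4 (0.50 log units; beyond the scatter) and bromo in place of chloro gives a 3.6-fold lower number from compound 2 to compound 4 (0.55 log units; beyond the scatter) in the same series, although chloro and trifluoromethyl had stood within the scatter of each other at this spot. The earlier tie therefore does not extend to every halogen, since bromo parts from chloro here even though both are halogens. Compound 4 is the only one of the four whose steps to all the others lie beyond the scatter, and that includes a 5.9-fold lower number from compound 1 to compound 4 (0.77 log units; beyond the scatter) with bromophenyl in place of phenethyl, while no measurement shown accounts for why bromo stands apart from chloro and trifluoromethyl.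

Still open, going by these compounds, is whether the lower number belongs to bromo alone or continues with iodo, and whether fluoro or methoxy on the same carbon would fall with chloro or with bromo. Also open, on these data alone, is whether a bromo on the phenyl ring of the phenethyl arm of compound 1 would bring the same kind of step.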